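This account rests on a few compounds, and the source may have more. Where it says the series, first, only, none or still open, it means among the compounds named here.

Values in an ADME assay on Vero cells (Chlorocebus sabaeus) for cytotoxicity, read by luminescence, with a stated time of 2 days; a lower number here means that less compound is tolerated, a higher number that more compound is tolerated:
Compound 1 `CCc1nc2ccccc2n1CCCOc1ccccc1`: > 50 uM
Compound 2 `CCc1nc2ccccc2n1CCCCOc1cccc(C)c1`: 19 uM
Compound 3 `CCc1nc2ccccc2n1CCCCOc1ccc(C)cc1`: 14 uM

Compound 3 gives 14 uM, and this lies within the scatter of compound 2 at 19 uM. Within the data shown here, these are the only two true numbers. The entry for compound 1 is a limit, > 50 uM, and not a number.

Compound 4 `CCc1nc2ccccc2n1CCCCOc1cccc(Cl)c1` carries 3-chlorophenyl in place of the 4-methylphenyl of compound 3, on an oxygen on a saturated carbon: 3-chlorophenyl in place of 4-methylphenyl on an oxygen on a saturated carbon. Among the measured compounds shown here, one measured step bears on this change: a 1.4-fold lower number from compound 2 to compound 3 (0.13 log units; within the scatter). It exchanges 3-methylphenyl for 4-methylphenyl at that same place and stays within the scatter. For the measured compounds named here, no measured step shows what chlorine does. Compound 1 differs from compound 3 in more than one place, so it offers no clean comparison.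

The step in this assay is therefore expected to stay within the scatter, with no direction favoured. The estimated change is a 1.1-fold higher number from compound 3 to compound 4 (0.03 log units; within the scatter). Compound 4 is expected at 15 uM, with an estimated range of 7 uM to 32 uM.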

Compound 4, half-maximal toxic concentration: 22 uM
Compound 4: middle estimate off by 1.5-fold (0.17 log units), on the low side; low and high end bracket the measured number.
By their numbers in this assay, from the lowest: compounds 3, 2 and 4 (each within the scatter of the next). At a limit, above all of these: compound 1.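

In this assay, among these compounds, chloro in place of methyl on an aromatic carbon gives a 1.2-fold higher number from compound 2 to compound 4 (0.06 log units; within the scatter) and so supplies the first measured step for chlorine. Replacing 4-methylphenyl with 3-chlorophenyl on the same oxygen gives a 1.6-fold higher number from compound 3 to compound 4 (0.20 log units; within the scatter), which means that compound 2, compound 3 and compound 4 all lie within the scatter of one another, and the assay does not separate these three groups at this place. Nothing shown gives a cause for these values.

Among the compounds shown here, compound 1 gives > 50 uM, which is a limit and not a number, and it differs from the other compounds in more than one place, so it yields no clean step. As far as these compounds go, whether an amine or a carboxylic acid on the aromatic ring would take the number beyond the scatter remains open.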